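Chain-end change in the hydroxycarbamoyl series: compound 3 to 4

The compounds below may be only part of what the source reports. "The series", "measured", "known", "first", "only" and "open" are said of these compounds alone.

Values in a functional assay on PLC-PRF-5 cells (Homo sapiens) for inhibition, read by MTT assay, with a stated time of 72 h; on this read-out lower numbers stand for stronger inhibition and higher numbers for weaker inhibition:
- Compound 1 `Nc1nc2cc(-c3nn(CCCCCCCCCC(=O)NO)c4ncnc(N)c34)ccc2o1`: > 100000 nM (a limit of the assay, not a number)
- Compound 2 `Nc1nc2cc(-c3nn(CCCCC(=O)NO)c4ncnc(N)c34)ccc2o1`: 29600 nM
- Compound 3 `Nc1nc2cc(-c3nn(CCCCCCCCC(=O)NO)c4ncnc(N)c34)ccc2o1`: 24000 nM

Among the compounds with values here, compound 2 and compound 3 hold the only two actual numbers, and they do not separate: a 1.2-fold lower number from compound 2 to compound 3 (0.09 log units; within the scatter). Compound 1 stands apart from both, with an at least 4.1-fold lower number from compound 1 to compound 3 (0.61 log units; beyond the scatter) and an at least 3.3-fold lower number from compound 1 to compound 2 (0.52 log units; beyond the scatter).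

Compound 4 `CNC(=O)CCCCCCCn1nc(-c2ccc3oc(N)nc3c2)c2c(N)ncnc21` differs from compound 3 at the chain end: methylcarbamoyl in place of (hydroxycarbamoyl)methyl on a saturated chain carbon, seven bonds along the chain from an aromatic nitrogen. In words, this is methylcarbamoyl in place of (hydroxycarbamoyl)methyl on a saturated chain carbon, seven bonds along the chain from an aromatic nitrogen.

Within the data shown here, all three measured compounds keep hydroxycarbamoyl, so no measured step tests its loss. The measured steps bear only on the chain-length part of the change. There, a 1.2-fold lower number from compound 2 to compound 3 (0.09 log units; within the scatter) shows no separation, while compound 1 goes against any flat trend with an at least 4.1-fold lower number from compound 1 to compound 3 (0.61 log units; beyond the scatter). A modest move towards weaker inhibition in this assay is therefore expected, though on thin evidence, and a limit rather than a number is a real possibility. The expected step is a 2.1-fold higher number from compound 3 to compound 4 (0.32 log units; beyond the scatter). For compound 4 the estimated value is 50000 nM, with an expected range of 12000 nM to 120000 nM.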

Compound 4, half-maximal inhibitory concentration: 30500 nM
Estimate against measurement, compound 4: 1.6-fold (0.21 log units) above; the range from low to high includes it.
By their numbers in this assay, from the lowest: compounds 3, 2 and 4 (each within the scatter of the next). At a limit, above all of these: compound 1.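

In this assay, methylcarbamoyl in place of (hydroxycarbamoyl)methyl on a saturated chain carbon, seven bonds along the chain from an aromatic nitrogen, gives a 1.3-fold higher number from compound 3 to compound 4 (0.10 log units; within the scatter), so this first test of the loss of the hydroxycarbamoyl end shows no separation. The comparison with the shorter hydroxycarbamoyl compound agrees, with a 1.0-fold higher number from compound 2 to compound 4 (0.01 log units; within the scatter), which puts compounds 2, 3 and 4 together on this read-out, whichever of the two chain ends they carry. Compound 1 stays apart, with an at least 3.2-fold lower number from compound 1 to compound 4 (0.51 log units; beyond the scatter), and its value is a limit of the assay, not a number: the limit of > 100000 nM in this assay, at which 1 of the 4 values shown sits.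

With only hydroxycarbamoyl and methylcarbamoyl at the chain end, it remains open whether a carboxylic acid, a primary amide or an amine at this place would also stay within the scatter of these compounds. Going by these compounds, it also remains open whether methylcarbamoyl on the longer chain of compound 1 would give a number or a limit, and whether a chain with an ether oxygen or a ring in it would leave this assay unchanged.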